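Compound 3 Leads as the Amide Group Changes Again

The source may report more compounds than this note shows. Statements on the series, on what has been measured and on what is new or still open speak of the compounds shown alone.

In an ADME assay on L02 cells (Homo sapiens) for antiproliferative activity, read by MTT assay, with a stated time of 48 h (on this read-out lower numbers stand for stronger inhibition and higher numbers for weaker inhibition), compound 1 `CCn1c(C(=O)NCC#N)ccc1C(CC)(CC)c1ccc(OCCC(O)(CC)CC)c(C)c1` gives > 50000 nM, which is a limit of the assay. Compound 2 `CCn1c(C(=O)N(CCC#N)CCC#N)ccc1C(CC)(CC)c1ccc(OCCC(O)(CC)CC)c(C)c1` gives 37800 nM, and compound 3 `C=CCN(C)C(=O)c1ccc(C(CC)(CC)c2ccc(OCCC(O)(CC)CC)c(C)c2)n1CC` gives 1190 nM, the lowest number of the three. Only the group on the carbonyl carbon separates these compounds. Among the measured compounds shown here, two steps bear most directly on what follows: a 32-fold lower number from compound 2 to compound 3 (1.50 log units; beyond the scatter) and an at least 42-fold lower number from compound 1 to compound 3 (1.62 log units; beyond the scatter). Both are large, so changes at this place can move the number strongly. Compound 4 `CCn1c(C(=O)Nc2cccc(C(F)(F)F)c2)ccc1C(CC)(CC)c1ccc(OCCC(O)(CC)CC)c(C)c1` differs from compound 3 at the same place: (3-(trifluoromethyl)phenyl)amino in place of allyl(methyl)amino on a carbonyl carbon. For the measured compounds named here, no measured compound carries an aromatic ring in this group, so the steps give only a rough guide. Compound 3 stands well below compound 2 at 37800 nM, and replacing its allyl(methyl)amino group is therefore expected to raise the number, probably by less than those steps. The expected change is a 5.0-fold higher number from compound 3 to compound 4 (0.70 log units; beyond the scatter). For compound 4 the estimated value is 6000 nM, within an expected range of 1200 nM to 40000 nM.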

Compound 4, half-maximal inhibitory concentration: > 50000 nM
Compound 4 ended at the assay's limit; the forecaster's own chance of this, stated with the estimate: 20%; middle value at least 8.3-fold (0.92 log units) away from the limit.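

Putting (3-(trifluoromethyl)phenyl)amino in place of allyl(methyl)amino on the carbonyl carbon gives an at least 42-fold higher number from compound 3 to compound 4 (1.62 log units; beyond the scatter) in this assay, so the first aromatic ring seen at this place comes with the complete loss of the low number held by compound 3. The other readable step is an at least 1.3-fold higher number from compound 2 to compound 4 (0.12 log units; that floor lies within the scatter), and that floor does not set these two compounds apart. The step between compound 1 and compound 4 cannot be read, as compound 1 and compound 4 each rest on a limit and give no number: the limit of > 50000 nM in this assay, at which 2 of the 4 values shown sit.

Going by these compounds, compound 4 brings in the aromatic ring, the trifluoromethyl group and the amide hydrogen all at once, so which of them goes with the loss stays open. On these data alone, how a plain phenylamino group or a dimethylamino group would read on this carbonyl carbon also remains unknown.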